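This account rests on a few compounds, and the source may have more. Where it says the series, first, only, none or still open, it means among the compounds named here.

Compound 1 `c1ccc2c(c1)CN[C@@H](CN(CCCCNCc1ccncc1)[C@H]1CCCc3cccnc31)C2` — > 30000 nM
Compound 2 `c1ccc2c(c1)CN[C@@H](CN(CCCCNC1CCOCC1)[C@H]1CCCc3cccnc31)C2` — > 30000 nM

Both measured compounds share one core and differ only at one amine nitrogen. In a functional assay on cells for agonist activity at C-X-C chemokine receptor type 4 (Homo sapiens), read by fluorescence and calcium flux, with a stated time of 90 s (a lower number here means that less compound is needed, a higher number that more compound is needed for the effect), compound 1 gives > 30000 nM, which is a limit of the assay and not a number. In this assay compound 2 gives > 30000 nM, again a limit rather than a number. For the measured compounds named here, the one measured step, a step that the two limits leave unreadable from compound 1 to compound 2, with oxan-4-yl in place of (pyridin-4-yl)methyl on an amine nitrogen, therefore cannot be read, because the limit of > 30000 nM in this assay, at which 2 of the 2 values shown sit, covers both values. Going by the values given here, compound 2 thus stands only at a limit, and the one further value shown is a limit too.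

Compound 3 `NCc1ccccc1CN(C[C@H]1Cc2ccccc2CN1)[C@H]1CCCc2cccnc21` differs from compound 2 by 2-(aminomethyl)phenyl in place of 3-((oxan-4-yl)amino)propyl on a saturated chain carbon bound to an amine nitrogen. Among the compounds with values here, no measured step bears on this change, and the single step on hand is unreadable, so no direction can be drawn from the data. Compound 3 is therefore expected to give about 20000 nM in this assay, within a wide range from 2000 nM to 100000 nM. This estimate means a step of an at least 1.5-fold lower number from compound 2 to compound 3 (0.17 log units; that floor lies within the scatter), with a limit the most likely outcome.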

Compound 3, half-maximal effective concentration: > 30000 nM
Compound 3 ended at the assay's limit (the forecaster's own chance of this, stated with the estimate: 60%); at least 1.5-fold (0.17 log units) between middle value and limit.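

In this assay compound 3 gives > 30000 nM, which is again a limit and not a number. The steps linking compound 1, compound 2 and compound 3 therefore cannot be read, because all three compounds stop at the same point: the limit of > 30000 nM in this assay, at which 3 of the 3 values shown sit.

The compounds shown leave open whether any of these groups on the shared core changes the concentration needed for the effect.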